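This account rests on a few compounds, and the source may have more. Where it says the series, first, only, none or still open, it means among the compounds named here.

Compound 1 `NC[C@@H]1CCCc2cc(S(=O)(=O)c3cccc(F)c3)ccc21` gives 0.0794 nM in an assay on isolated protein for displacement of a labelled ligand from 5-hydroxytryptamine receptor 6 (Homo sapiens); on this read-out higher numbers stand for weaker inhibition and lower numbers for stronger inhibition. Compound 2 `O=C(NC[C@@H]1CCCc2cc(S(=O)(=O)c3cccc(F)c3)ccc21)[C@H]1CCCN1` gives 0.631 nM in this assay, the step being a 7.9-fold higher number from compound 1 to compound 2 (0.90 log units; beyond the scatter). Compound 3 `O=S(=O)(c1cccc(F)c1)c1ccc2c(c1)CCC[C@H]2CN1CC(O)C1` gives 0.1 nM in this assay; from compound 1 the step is a 1.3-fold higher number from compound 1 to compound 3 (0.10 log units; within the scatter), and a 6.3-fold lower number from compound 2 to compound 3 (0.80 log units; beyond the scatter). Compound 3 thus sits between the other two, within the scatter of compound 1 and clearly apart from compound 2. Compound 4 `O=C1CN(C[C@@H]2CCCc3cc(S(=O)(=O)c4cccc(F)c4)ccc32)CCN1` differs from compound 3 by 3-oxopiperazin-1-yl in place of 3-hydroxyazetidin-1-yl on a saturated chain carbon bound to a saturated ring carbon. The step from compound 1 to compound 3 shows that swapping the amino group for a ring at this carbon changed little, whereas the step from compound 1 to compound 2 shows that a larger attachment weakened binding modestly. Compound 4 is therefore expected to show a 2.0-fold higher number from compound 3 to compound 4 (0.30 log units; within the scatter). Compound 4 is expected to give 0.2 nM, between 0.06 nM and 0.7 nM.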

Compound 4, inhibition constant: 6.31 nM
Compound 4: the middle estimate sits 32-fold (1.50 log units) below what was measured, and the stated range ends below it.
By their numbers in this assay, from the lowest: compounds 1 and 3 (each within the scatter of the next); then compound 2; then compound 4.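

On a saturated chain carbon bound to a saturated ring carbon, not every ring is tolerated: placing 3-oxopiperazin-1-yl there gives a 63-fold higher number from compound 3 to compound 4 (1.80 log units; beyond the scatter) and a 79-fold higher number from compound 1 to compound 4 (1.90 log units; beyond the scatter) even though 3-hydroxyazetidin-1-yl stayed within the scatter of the amino group. This ring also does worse than the ((pyrrolidin-2-yl)carbonyl)amino group, with a 10-fold higher number from compound 2 to compound 4 (1.00 log units; beyond the scatter) as the step. Nothing measured here explains the loss.

Going by these compounds, it remains open whether the loss goes with the six-membered ring or with its carbonyl. A plain piperazin-1-yl group at this carbon could help separate the two.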